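Swapping Trifluoromethyl for Chloro on the Urea Aryl Ring

A few compounds are considered here, and "the series" means these few. Any claim that something is new, unique, unknown or untested is made for them only; others in the source may bear on it.

Measured compounds:
Compound 1, `O=C(Nc1cccc(-n2cc(-c3ccncc3)c(-c3cc(O)cc(Cl)c3)n2)c1)Nc1ccc(Cl)c(C(F)(F)F)c1`, gives 103%.
Compound 2, `O=C(Nc1cccc(-n2cc(-c3ccncc3)c(-c3cc(O)cc(Cl)c3)n2)c1)Nc1ccc(Cl)c(Cl)c1`, gives 98%.
Compound 3, `COc1cc(Cl)cc(-c2nn(-c3cccc(NC(=O)Nc4ccc(Cl)c(C(F)(F)F)c4)c3)cc2-c2ccncc2)c1`, gives 99%.

These three compounds share one core and were tested in a functional assay on CAKI-1 cells (Homo sapiens) for inhibition, read by sulforhodamine B assay, with a stated time of 48 h, tested at 0.1 uM; on this read-out higher numbers stand for a weaker effect at the one concentration tested and lower numbers for a stronger effect. All three numbers sit close together: compound 3 is nearest to compound 2, and the change of methyl in place of hydrogen on the ring oxygen reads a number 4 percentage points lower from compound 1 to compound 3 (within the scatter). Nothing among them separates beyond the scatter.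

Compound 4, `COc1cc(Cl)cc(-c2nn(-c3cccc(NC(=O)Nc4ccc(Cl)c(Cl)c4)c3)cc2-c2ccncc2)c1`, has not yet been measured. It differs from compound 3 in one place: chloro in place of trifluoromethyl on an aromatic carbon. The same change has already been seen once, between compound 1 and compound 2, where it gave a number 5 percentage points lower from compound 1 to compound 2 (within the scatter). For the measured compounds named here, that earlier step is the only direct guide, and it stayed inside the scatter.

On that basis the expected step in this assay from compound 3 to compound 4 is a number 4 percentage points lower from compound 3 to compound 4 (within the scatter), a small shift that need not be real. Compound 4 is therefore estimated at 95%, with a likely range from 85% to 105%.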

Compound 4, a percentage reported as activity, at one concentration (the size of the read-out at that concentration, not a potency): 102%
Beside the measured number, compound 4's estimate is 7 percentage points below it; low and high end bracket the measured number.
By their numbers in this assay, from the lowest: compounds 2, 3, 4 and 1 (each within the scatter of the next).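

On the core carrying methyl on the ring oxygen, chloro in place of trifluoromethyl reads as a number 3 percentage points higher from compound 3 to compound 4 (within the scatter), so in this assay this change can now be compared on two cores, and its two readings agree within the scatter: the same change on two cores in this assay, a number 5 percentage points lower (within the scatter) from compound 1 to compound 2 and a number 3 percentage points higher (within the scatter) from compound 3 to compound 4, 8 percentage points apart, within the scatter of two such steps. Methyl in place of hydrogen on the ring oxygen also gains a second reading, a number 4 percentage points higher from compound 2 to compound 4 (within the scatter), and these two readings agree in the same way: the same change on two cores in this assay, a number 4 percentage points lower (within the scatter) from compound 1 to compound 3 and a number 4 percentage points higher (within the scatter) from compound 2 to compound 4, 8 percentage points apart, within the scatter of two such steps. Neither change, on either core, separates any pair of compounds it connects at this one concentration.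

On these data alone, whether a nitrile or an amine on this aromatic carbon, or a longer chain on the ring oxygen, would move the number beyond the scatter stays open. The four compounds also leave open how these changes would read at other concentrations.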